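Amide to sulfonamide on a shared cinnamoyl-benzimidazole core

The compounds below may be only part of what the source reports. "The series", "measured", "known", "first", "only" and "open" are said of these compounds alone.

Measured so far:
compound 1 `Cc1ccccc1C(=O)Nc1cccc(/C=C/C(=O)c2nc3ccccc3[nH]2)c1`, 8290 nM
compound 2 `COc1cccc(C(=O)Nc2cccc(/C=C/C(=O)c3nc4ccccc4[nH]3)c2)c1`, 4610 nM

In a functional assay on 143B cells (Homo sapiens) for antiproliferative activity, read by MTT assay, with a stated time of 48 h (on this read-out higher numbers stand for weaker inhibition and lower numbers for stronger inhibition), compound 2 gives the lower of the two numbers, yet its gap to compound 1 is within the scatter: a 1.8-fold lower number from compound 1 to compound 2 (0.25 log units; within the scatter). Compound 3 `O=C(/C=C/c1cccc(NS(=O)(=O)c2ccccc2Cl)c1)c1nc2ccccc2[nH]1` carries (2-chlorophenyl)sulfonyl in place of (3-methoxyphenyl)carbonyl on a nitrogen on an aromatic ring. No measured step touches this change; the only step shown swaps one aryl ring on the carbonyl for another, and it stayed within the scatter. The study therefore has no ground for expecting a shift beyond the scatter, so compound 3 is estimated at 5000 nM (range 1500 nM to 16000 nM), a step of a 1.1-fold higher number from compound 2 to compound 3 (0.04 log units; within the scatter) that is expected, not measured.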

Compound 3, half-maximal inhibitory concentration: 4790 nM
For compound 3 the middle estimate is 1.0-fold (0.02 log units) above the measured one, within the range that was stated.
By their numbers in this assay, from the lowest: compounds 2, 3 and 1 (each within the scatter of the next).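

In this assay, exchanging the aryl carbonyl on the nitrogen for (2-chlorophenyl)sulfonyl gives a 1.0-fold higher number from compound 2 to compound 3 (0.02 log units; within the scatter) and a 1.7-fold lower number from compound 1 to compound 3 (0.24 log units; within the scatter). The earlier step had changed only the aryl ring on the carbonyl, whereas these show that replacing the carbonyl with a sulfonyl at this nitrogen also stays within the scatter. Nothing available explains why the two linkages read alike. The compounds shown leave open whether an amine or a carboxylic acid on the aryl ring, or a longer chain in its place, would move the number beyond the scatter.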